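Series notes: branching of the acyl chain in the shared core

The source may report more compounds than this note shows. Statements on the series, on what has been measured and on what is new or still open speak of the compounds shown alone.

In a functional assay on HEK293 cells for positive allosteric modulation of metabotropic glutamate receptor 5 (Homo sapiens), read by calcium flux (on this read-out higher numbers stand for larger maximal responses and lower numbers for smaller maximal responses), compound 1 `CCC(=O)N1CCCn2nc(COc3ccccc3)cc21` gives 48% and compound 2 `CC(C)C(=O)N1CCCn2nc(COc3ccccc3)cc21` gives 59%. Among the compounds with values here, the single measured step, a number 11 percentage points higher from compound 1 to compound 2 (beyond the scatter), comes from methyl in place of hydrogen on a saturated chain carbon bound to a carbonyl carbon and a saturated chain carbon. Within the data shown here, on these two numbers compound 2 stands highest, with compound 1 the only neighbour and lower beyond the scatter.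

Compound 3 `CC(C)(C)C(=O)N1CCCn2nc(COc3ccccc3)cc21` differs from compound 2 by methyl in place of hydrogen on a saturated chain carbon bound to a carbonyl carbon and two saturated chain carbons. The step from compound 1 to compound 2 is the only one that bears on it: the same kind of change, one methyl added at the same place, gave a modest rise. A second methyl at that place is expected to move this assay less, so an expected step of a number 4 percentage points higher from compound 2 to compound 3 (within the scatter) is assumed, upward but possibly within scatter. Compound 3 is therefore estimated at 63%, with a range from 48% to 78%.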

Compound 3, largest response reached (reported as percent of maximum), in percent of the reference or control that the assay uses: 64%
Beside the measured number, compound 3's estimate is 1 percentage points below it, within the range that was stated.
By their numbers in this assay, from the lowest: compound 1; then compounds 2 and 3 (each within the scatter of the next).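

In this assay, within the data shown here, the second methyl at this place, on a saturated chain carbon bound to a carbonyl carbon and two saturated chain carbons, gives a number 5 percentage points higher from compound 2 to compound 3 (within the scatter), so isopropyl and tert-butyl cannot be told apart here, whereas the first methyl gave a step beyond the scatter. Across the whole change, tert-butyl in place of ethyl on a carbonyl carbon gives a number 16 percentage points higher from compound 1 to compound 3 (beyond the scatter), a difference that remains beyond the scatter. No available evidence bears on the reason for these numbers.

With tert-butyl, this carbon carries no hydrogen for a further methyl to replace. The compounds shown leave open how a cyclopropyl ring, a longer chain or an amine on the same carbonyl carbon would read out in this assay, and whether any of these would stand apart from compound 3.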